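The compounds below may be only part of what the source reports. "The series", "measured", "known", "first", "only" and "open" are said of these compounds alone.

Measured so far in an assay on cells for inhibition of HSP60/HSP10 (Homo sapiens), with a stated time of 60 min; a higher number here means a weaker inhibitor, a lower number a stronger inhibitor:
compound 1 `C=Cc1ccc(S(=O)(=O)Nc2ccc3oc(-c4ccccc4)nc3c2)cc1`: > 100000 nM, a limit of the assay.
compound 2 `O=S(=O)(Nc1ccc2oc(-c3ccccc3)nc2c1)c1ccc(F)c(C(F)(F)F)c1`: 69000 nM.
compound 3 `O=S(=O)(Nc1ccc2oc(-c3ccccc3)nc2c1)c1ccc(C(F)(F)F)cc1`: > 100000 nM, also a limit of the assay.

Compound 1 therefore stands only at a limit, not at a number, in this assay; it sits at the limit (the limit of > 100000 nM in this assay, at which 2 of the 3 values shown sit). Compound 4 `O=S(=O)(Nc1ccc2oc(-c3ccccc3)nc2c1)c1ccc(Cl)s1` differs from compound 1 by one change: 5-chlorothiophen-2-yl in place of 4-vinylphenyl on a sulfonyl sulfur. Among the measured compounds shown here, the one measured step that touches compound 1, a step that the two limits leave unreadable from compound 1 to compound 3, starts and ends at the limit, so its size cannot be read, and no measured step involves a 5-chlorothiophen-2-yl group. For the measured compounds named here, compound 2 gives 69000 nM, the only number among the three. With no readable step to lean on, compound 4 is expected to stay weak, with an estimated step of an at least 1.1-fold lower number from compound 1 to compound 4 (0.04 log units; that floor lies within the scatter) that is uncertain against a limit. The estimate for compound 4 in this assay is 90000 nM, with a range from 25000 nM to 300000 nM.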

Compound 4, half-maximal inhibitory concentration: 70000 nM
For compound 4 the middle estimate is 1.3-fold (0.11 log units) above the measured one; the range from low to high includes it.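

In this assay, compound 4 shows that a five-membered aromatic ring on the sulfonyl sulfur can give a readable number. Putting 5-chlorothiophen-2-yl in place of 4-vinylphenyl gives an at least 1.4-fold lower number from compound 1 to compound 4 (0.15 log units; that floor lies within the scatter), the first size that can be put on a change from compound 1. The value of compound 1 is a limit, so only this floor is known, and its other step cannot be read.

Going by these compounds, it remains open whether the chlorine or the ring matters more. Also open, on these data alone, is how an amine or a carboxylic acid on the ring would read.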